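The source may report more compounds than this note shows. Statements on the series, on what has been measured and on what is new or still open speak of the compounds shown alone.

Of the compounds shown here, three sharing one core have been measured in a functional assay on MCF7 cells (Homo sapiens) for cytotoxicity, read by MTT assay, with a stated time of 72 h; a lower number here means a stronger inhibitor, a higher number a weaker inhibitor. Compound 1 `O=C(/C=C/c1ccc([N+](=O)[O-])cc1)Nc1cc2c(Nc3ccc(F)c(Cl)c3)ncnc2cc1O[C@H]1CCOC1` gives 26700 nM, compound 2 `COc1cc(/C=C/C(=O)Nc2cc3c(Nc4ccc(F)c(Cl)c4)ncnc3cc2O[C@H]2CCOC2)cc(OC)c1OC` gives 28400 nM, and compound 3 `O=C(/C=C/c1cc(Br)c(O)c(Br)c1)Nc1cc2c(Nc3ccc(F)c(Cl)c3)ncnc2cc1O[C@H]1CCOC1` gives 30600 nM. Compound 2 stands second highest of the three numbers, yet within the scatter of both others: a 1.1-fold higher number from compound 1 to compound 2 (0.03 log units; within the scatter) and a 1.1-fold higher number from compound 2 to compound 3 (0.03 log units; within the scatter), just as a 1.1-fold higher number from compound 1 to compound 3 (0.06 log units; within the scatter). Compound 4 `COc1cc2ncnc(Nc3ccc(F)c(Cl)c3)c2cc1NC(=O)/C=C/c1cc(OC)c(OC)c(OC)c1` differs from compound 2 by methyl in place of oxolan-3-yl on an oxygen on an aromatic ring. Within the data shown here, none of the measured steps touches this oxygen; all three vary the group on a double-bonded chain carbon and all stay within the scatter, so there is no measured guide to the size of this change. The expected step of a 1.0-fold lower number from compound 2 to compound 4 (0.01 log units; within the scatter) is therefore none beyond the scatter. Compound 4 is expected to give 28000 nM, within 9000 nM to 85000 nM.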

Compound 4, half-maximal inhibitory concentration: "not active" (no number reported)
The entry for compound 4 holds no number, and the estimate cannot be compared.
By their numbers in this assay, from the lowest: compounds 1, 2 and 3 (each within the scatter of the next).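

In this assay, among these compounds, compound 4 is entered as not active with no number, so no step linking it to compound 1, compound 2 or compound 3 can be read. As far as these compounds go, what methoxy in place of (oxolan-3-yl)oxy does to the number stays open, and no evidence at hand bears on this result.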